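Triazole substituent series: aryl replacement on the shared core

This account rests on a few compounds, and the source may have more. Where it says the series, first, only, none or still open, it means among the compounds named here.

Compound 2 `CCCCCCCc1cn(C(c2ccccc2)c2cc3cc(Br)ccc3nc2OC)nn1` stands lowest of the two measured numbers: in an ADME assay on PC-3 cells (Homo sapiens) for cytotoxicity, read by sulforhodamine B assay, with a stated time of 48 h, tested at 10 uM (a higher number here means more inhibition at the concentration tested (going by the name of the read-out), a lower number less inhibition), compound 2 gives 4.42%, while compound 1 `COc1nc2ccc(Br)cc2cc1C(c1ccccc1)n1cc(C2CC2)nn1` gives 22.6% in this assay, a step of a number 18.2 percentage points lower from compound 1 to compound 2 (beyond the scatter). Compound 3 `COc1nc2ccc(Br)cc2cc1C(c1ccccc1)n1cc(-c2ccc(OC(F)(F)F)cc2)nn1` carries the change (4-(trifluoromethoxy)phenyl in place of heptyl on an aromatic carbon). Among the measured compounds shown here, only the cyclopropyl-to-heptyl step bears on it, and it shows that this position moves the read-out; no measured step covers an aromatic substituent there. Compound 3 is therefore expected to climb back modestly, an estimated step of a number 9.6 percentage points higher from compound 2 to compound 3 (within the scatter), to an expected 14% with a range of -2% to 32%.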

Compound 3, a percentage reported as inhibition, at one concentration (the size of the read-out at that concentration, not a potency): 21.6%
Beside the measured number, compound 3's estimate is 7.6 percentage points below it, and the stated range covers the measured number.
By their numbers in this assay, from the lowest: compound 2; then compounds 3 and 1 (each within the scatter of the next).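

Replacing heptyl with 4-(trifluoromethoxy)phenyl on this aromatic carbon gives a number 17.2 percentage points higher from compound 2 to compound 3 (beyond the scatter) in this assay, so an aromatic ring at this position restores the read-out. Set against cyclopropyl, the same group gives a number 1 percentage points lower from compound 1 to compound 3 (within the scatter), which leaves the two indistinguishable. Among these three compounds the low number therefore belongs to heptyl alone, not to every group larger than cyclopropyl.

Nothing at hand accounts for the heptyl result. Open, going by these compounds, is how a shorter chain such as butyl, or an amine or a carboxylic acid, would read at this position.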